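Side-chain changes on the shared core: compound 4

The source may report more compounds than this note shows. Statements on the series, on what has been measured and on what is new or still open speak of the compounds shown alone.

Measured so far:
Compound 1, `C[C@H](NC(=O)CN(c1nc(Cl)nc2c1ncn2C1CCCCO1)C1CC1)C(=O)OCc1ccccc1`, in a functional assay on the whole organism with Mus musculus as the target, with a stated time of 90 min, at a dose of 25 umol/kg by the oral route (on this read-out higher numbers stand for a stronger effect at the one dose given and lower numbers for a weaker effect), gives 32.1%.
Compound 2, `N=C(N)NCCC[C@H](NC(=O)CN(c1nc(Cl)nc2c1ncn2C1CCCCO1)C1CC1)C(=O)OCc1ccccc1`, in this assay gives 61.6%.
Compound 3, `O=C(CN(c1nc(Cl)nc2c1ncn2C1CCCCO1)C1CC1)N[C@@H](CC(=O)OCc1ccccc1)C(=O)OCc1ccccc1`, in this assay gives 25.1%.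

Compound 3 has the lowest of the three numbers in this assay. Its value and that of compound 1 lie within the scatter of each other, so no order between them is claimed; the step of a number 7 percentage points lower from compound 1 to compound 3 (within the scatter) carries no weight. Against compound 2 the gap is clear: a number 36.5 percentage points lower from compound 2 to compound 3 (beyond the scatter), and in the other direction a number 29.5 percentage points higher from compound 1 to compound 2 (beyond the scatter).

Compound 4, `NC(=O)CC[C@H](NC(=O)CN(c1nc(Cl)nc2c1ncn2C1CCCCO1)C1CC1)C(=O)OCc1ccccc1`, is not yet measured. It differs from compound 3 by carbamoylmethyl in place of benzyloxycarbonyl on a saturated chain carbon, two bonds along the chain from an amide-type nitrogen and a carbonyl carbon.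

For the measured compounds named here, two measured steps bear on this. Exchanging the benzyloxycarbonyl of compound 3 for hydrogen changed nothing beyond the scatter, whereas the nitrogen-bearing group of compound 2 went with a large rise. Carbamoylmethyl is a small group with one hydrogen-bond donor and one acceptor, closer in size to the change in compound 1 than to that in compound 2. A small rise is therefore expected, a number 10.9 percentage points higher from compound 3 to compound 4 (beyond the scatter), though it may well stay within the scatter.

For compound 4 in this assay the expected value is 36%, with a range from 22% to 54%.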

Compound 4, a percentage reported as activity, at one dose (the size of the read-out at that dose, not a potency): 37.8%
Compound 4: middle estimate off by 1.8 percentage points, on the low side; the range from low to high includes it.
By their numbers in this assay, from the lowest: compounds 3, 1 and 4 (each within the scatter of the next, the first and the last beyond it); then compound 2.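

Carbamoylmethyl in place of benzyloxycarbonyl, on the saturated chain carbon two bonds along the chain from an amide-type nitrogen and a carbonyl carbon, gives a number 12.7 percentage points higher from compound 3 to compound 4 (beyond the scatter) in this assay, so a step beyond the scatter at this position does not depend on the group of 6 heavy atoms (3 carbon, 3 nitrogen; no ring) carried by compound 2. That step has to be read with care, since carbamoylmethyl in place of hydrogen gives only a number 5.7 percentage points higher from compound 1 to compound 4 (within the scatter), and compound 1 therefore cannot be told apart from either compound 3 or compound 4. The nitrogen-rich group of compound 2 remains separate from the carbamoyl-ended chain, with a number 23.8 percentage points lower from compound 2 to compound 4 (beyond the scatter), so the amide end does not reproduce what that group shows in this assay.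

Nothing at hand accounts for any of these steps. Still open, as far as these compounds go, is whether a primary amine or a carboxylic acid at the end of this side chain, or a longer chain ending in the same carbamoyl group, would come nearer to compound 2 at 61.6% in this assay.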